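Swapping chloro for methyl on the phenyl ring

This account rests on a few compounds, and the source may have more. Where it says the series, first, only, none or still open, it means among the compounds named here.

Of the compounds shown here, three sharing one core have been measured in a functional assay on MCF7 cells (Homo sapiens) for inhibition, read by CCK-8 assay; on this read-out higher numbers stand for weaker inhibition and lower numbers for stronger inhibition. Compound 1 `Oc1ccccc1/C=N/c1nnc(SCc2nnc(-c3ccccc3)o2)s1` gives 9760 nM, compound 2 `Oc1ccccc1/C=N/c1nnc(SCc2nnc(-c3ccc(Cl)cc3)o2)s1` gives 7550 nM and compound 3 `Cc1cccc(-c2nnc(CSc3nnc(/N=C/c4ccccc4O)s3)o2)c1` gives 11600 nM. Compound 2 has the lowest number of the three, yet both neighbours stay within the scatter: a 1.3-fold lower number from compound 1 to compound 2 (0.11 log units; within the scatter) and a 1.5-fold higher number from compound 2 to compound 3 (0.19 log units; within the scatter). Compound 4 `Cc1ccc(-c2nnc(CSc3nnc(/N=C/c4ccccc4O)s3)o2)cc1` differs from compound 2 by methyl in place of chloro on an aromatic carbon. Within the data shown here, the steps that bear on this change, a 1.3-fold lower number from compound 1 to compound 2 (0.11 log units; within the scatter) and a 1.2-fold higher number from compound 1 to compound 3 (0.08 log units; within the scatter), are both within the scatter, so no step beyond the scatter is expected in this assay for compound 4 either. The estimate for compound 4 is therefore 9500 nM, with a range from 4500 nM to 20000 nM, which corresponds to an expected step of a 1.3-fold higher number from compound 2 to compound 4 (0.10 log units; within the scatter).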

Compound 4, half-maximal inhibitory concentration: 8750 nM
Beside the measured number, compound 4's estimate is 1.1-fold (0.04 log units) above it; measured number inside the range.
By their numbers in this assay, from the lowest: compounds 2, 4, 1 and 3 (each within the scatter of the next).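

In this assay, methyl in place of chloro on the aromatic carbon para to a large group leaves the number within the scatter (a 1.2-fold higher number from compound 2 to compound 4 (0.06 log units; within the scatter)). The 4-methylphenyl group also stays within the scatter of the unsubstituted phenyl ring (a 1.1-fold lower number from compound 1 to compound 4 (0.05 log units; within the scatter)) and of the 3-methylphenyl group (a 1.3-fold lower number from compound 3 to compound 4 (0.12 log units; within the scatter)), so neither this substituent nor its ring position separates these compounds. Nothing available explains this flat result. On these data alone, whether an amine, a carboxylic acid or a longer chain at this place would give a step beyond the scatter stays open.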